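Furan for Thiophene on a Shared Core: Second Instance

The source may report more compounds than this note shows. Statements on the series, on what has been measured and on what is new or still open speak of the compounds shown alone.

Measured compounds:
compound 1 `Oc1cccc(-c2cc(-c3cccc(Cl)c3)nc(-c3ccco3)c2)c1`, 2460 nM
compound 2 `Oc1cccc(-c2cc(-c3ccsc3)nc(-c3cccc(Cl)c3)c2)c1`, 2510 nM
compound 3 `Oc1cccc(-c2cc(-c3ccsc3)nc(-c3ccccc3Cl)c2)c1`, 2500 nM

All three were tested in a functional assay on HCT-15 cells (Homo sapiens) for cytotoxicity, read by CCK-8 assay and cell counting, with a stated time of 2 days; a higher number here means a weaker inhibitor, a lower number a stronger inhibitor. Compound 4 `Oc1cccc(-c2cc(-c3ccco3)nc(-c3ccccc3Cl)c2)c1` remains unmeasured. It differs from compound 3 by furan-2-yl in place of thiophen-3-yl on an aromatic carbon. The same kind of change has already been made once among the measured compounds, from compound 2 to compound 1 (furan-2-yl in place of thiophen-3-yl on an aromatic carbon), where the surrounding place was meta to a 3-chlorophenyl group rather than a 2-chlorophenyl group; that step was a 1.0-fold lower number from compound 2 to compound 1 (0.01 log units; within the scatter). The two cores differ by 2-chlorophenyl in place of 3-chlorophenyl on an aromatic carbon, and that step was a 1.0-fold lower number from compound 2 to compound 3 (0.00 log units; within the scatter). Since the earlier instance of the change lay within the scatter, compound 4 is expected to sit close to compound 3, with an estimated step of no change at the digits printed from compound 3 to compound 4 (within the scatter). The estimate for compound 4 in this assay is 2500 nM, in the range 1500 nM to 4200 nM.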

Compound 4, half-maximal inhibitory concentration: 2230 nM
Compound 4: middle estimate off by 1.1-fold (0.05 log units), on the high side, and the stated range covers the measured number.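

In this assay, within the data shown here, furan-2-yl in place of thiophen-3-yl gives a 1.1-fold lower number from compound 3 to compound 4 (0.05 log units; within the scatter), and this agrees with the earlier instance of the change: the same change on two cores in this assay, a 1.0-fold lower number (0.01 log units; within the scatter) from compound 2 to compound 1 and a 1.1-fold lower number (0.05 log units; within the scatter) from compound 3 to compound 4, 1.1-fold (0.04 log units) apart, within the scatter of two such steps Likewise, 2-chlorophenyl in place of 3-chlorophenyl gives a 1.1-fold lower number from compound 1 to compound 4 (0.04 log units; within the scatter), which agrees with its own earlier instance: the same change on two cores in this assay, a 1.0-fold lower number (0.00 log units; within the scatter) from compound 2 to compound 3 and a 1.1-fold lower number (0.04 log units; within the scatter) from compound 1 to compound 4, 1.1-fold (0.04 log units) apart, within the scatter of two such steps Each change thus leaves the number within the scatter on both cores, but this shows only that neither swap moved the number on these two cores, not that these groups do not matter or that the same would hold on any other core.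

All four compounds keep the 3-hydroxyphenyl group and a chlorophenyl group. The compounds shown leave open whether a methoxy group in place of that hydroxyl, or an amine or a carboxylic acid on the chlorophenyl ring, would shift the number beyond the scatter.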